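A few compounds are considered here, and "the series" means these few. Any claim that something is new, unique, unknown or untested is made for them only; others in the source may bear on it.

Measured compounds:

Compound 1, `Cc1ccccc1NC(=O)N[C@@H](C)c1ccccc1`: 100%
Compound 2, `CCc1ccccc1NC(=O)N[C@@H](C)c1ccccc1`: 100%
Compound 3, `C[C@@H](NC(=O)Nc1ccccc1C(C)(C)C)c1ccccc1`: 100%

All three were tested in an ADME assay on the whole organism with Oryza sativa as the target, tested at 0.1 uM; a lower number here means a stronger effect, a higher number a weaker effect of the compound at the concentration tested. In this assay compound 1 gives 100%, and compound 2 gives 100%, so the step of no change at the digits printed from compound 1 to compound 2 (within the scatter) is flat. Compound 3 gives 100% in this assay, level with compound 1 and compound 2 at the digits shown; the three numbers are within the scatter of one another.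

The next compound, compound 4, is `C[C@H](NC(=O)Nc1ccccc1C(C)(C)C)c1ccccc1`. It differs from compound 3 only in configuration: the two compounds have the same atoms and bonds and differ only in configuration as drawn: 1 of 1 stereo elements differ; a stereocentre at a saturated chain carbon is drawn R in compound 3 and S in compound 4. Within the data shown here, no measured step concerns such an inversion; the one step on record, no change at the digits printed from compound 1 to compound 2 (within the scatter), concerns a methyl in place of hydrogen and was flat, and it bears on this change only in showing that small edits around this core left the read-out unmoved. With every measured compound at the same level, compound 4 is expected to stay there as well, with an expected step of no change at the digits printed from compound 3 to compound 4 (within the scatter) not beyond the scatter. Compound 4 is therefore estimated at 100% in this assay, within a range from 88% to 100%.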

Compound 4, a percentage reported as activity, at one concentration (the size of the read-out at that concentration, not a potency): 101%
For compound 4 the middle estimate is 1 percentage points below the measured one; the measured number lies above the stated range.
By their numbers in this assay, from the lowest: compounds 1, 2, 3 and 4 (each within the scatter of the next).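

In this assay the saturated chain carbon can now be judged on its own, and inverting its stereocentre gives a number 1 percentage points higher from compound 3 to compound 4 (within the scatter); the comparison is a clean one: the fact that compounds 3 and 4 differ only in the configuration as drawn. With the S centre in place, tert-butyl in place of ethyl gives a number 1 percentage points higher from compound 2 to compound 4 (within the scatter), and tert-butyl in place of methyl gives a number 1 percentage points higher from compound 1 to compound 4 (within the scatter). Across these four compounds, then, neither the drawn configuration nor the choice among these three alkyl groups on the aromatic carbon separates the read-outs beyond the scatter.

Because all four compounds sit level, they do not show which kind of edit, if any, would move this number. On these data alone, it remains open whether a hydroxyl group or a carboxylic acid in place of the tert-butyl would leave the read-out where it stands.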